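The source may hold more compounds than are shown below. What is called first, only, known or untested is meant among the compounds shown, and "the series" means these compounds.

Measured compounds, all read in a functional assay on CHO cells for agonist activity at Alpha-1B adrenergic receptor (Homo sapiens), read by FLIPR and calcium flux; a higher number here means that more compound is needed for the effect, a lower number that less compound is needed:
Compound 1, `CCCS(=O)(=O)Nc1cccc2c1CCC2c1ncc[nH]1`: compound 1 gives > 10000 nM, a limit of the assay.
Compound 2, `CCS(=O)(=O)Nc1cccc2c1CCC2c1ncc[nH]1`: compound 2 gives > 10000 nM, a limit of the assay.
Compound 3, `CNC(=O)c1cccc2c1CCC2c1ncc[nH]1`: compound 3 gives > 10000 nM, a limit of the assay.

Compound 3 thus stands where the whole series stands so far: the limit of > 10000 nM in this assay, at which 3 of the 3 values shown sit. The step from compound 1 to compound 2, hydrogen in place of methyl on a saturated chain carbon two bonds along the chain from a sulfonyl sulfur, is a step that the two limits leave unreadable from compound 1 to compound 2. The two steps that lead to compound 3, methylcarbamoyl in place of (propylsulfonyl)amino and methylcarbamoyl in place of (ethylsulfonyl)amino on an aromatic carbon, are a step that the two limits leave unreadable from compound 1 to compound 3 and a step that the two limits leave unreadable from compound 2 to compound 3. None of the three steps has a readable size, so nothing in the measured set shows that any change at this aromatic carbon moves the read-out at all.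

Compound 4 is `Cn1nccc1-c1cccc2c1CCC2c1ncc[nH]1`. It differs from compound 3 by 1-methyl-1H-pyrazol-5-yl in place of methylcarbamoyl on an aromatic carbon. Within the data shown here, no measured step resembles this change, and the measured steps give no size to lean on, so the expectation can only be loose. The estimate for compound 4 in this assay is 8000 nM, within 1000 nM to 30000 nM. The step this estimate implies is an at least 1.2-fold lower number from compound 3 to compound 4 (0.09 log units; that floor lies within the scatter), with a fair chance that only a limit is reported again.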

Compound 4, half-maximal effective concentration: > 10000 nM
Compound 4: no number, only a limit (the forecaster's own chance of this, stated with the estimate: 60%); middle value at least 1.2-fold (0.09 log units) from the limit.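

Compound 4 gives > 10000 nM, a limit of the assay, so its steps from compound 1, compound 2 and compound 3 cannot be read. All four compounds sit together: the limit of > 10000 nM in this assay, at which 4 of the 4 values shown sit. The compounds shown leave open whether any group on this aromatic carbon of the shared core moves the read-out at all, and by how much.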